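Swapping a pyridine substituent on the shared core

The source may hold more compounds than are shown below. What is called first, only, known or untested is meant among the compounds shown, and "the series" means these compounds.

Compound 2 `CCC(C)(C)Cc1c[nH]c(CCc2ccc(-c3ccc(F)cn3)cc2)n1` and compound 1 `CCC(C)(C)Cc1c[nH]c(CCc2ccc(-c3cccc(C#N)n3)cc2)n1` share the same core and differ only in the pyridine substituent. In a functional assay on HEK293 cells for agonist activity at Bombesin receptor subtype-3 (Mus musculus), read by luminescence and calcium flux, with a stated time of 10 min (on this read-out lower numbers stand for an effect already at smaller amounts and higher numbers for an effect only at larger amounts of compound), compound 2 gives 16 nM, and compound 1 gives 26 nM. Among the measured compounds shown here, the step of a 1.6-fold lower number from compound 1 to compound 2 (0.21 log units; within the scatter) is the only measured change at this position, and it stays within the scatter, so the two numbers cannot be told apart with confidence.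

Compound 3 `CCC(C)(C)Cc1c[nH]c(CCc2ccc(-c3cccc(N)n3)cc2)n1` differs from compound 2 by 6-aminopyridin-2-yl in place of 5-fluoropyridin-2-yl on an aromatic carbon. For the measured compounds named here, the one step that bears on this kind of change, from compound 1 to compound 2, was small, but it compared two other substituents; no measured step involves an amino group here. The expectation is therefore a step of about a 1.6-fold higher number from compound 2 to compound 3 (0.19 log units; within the scatter) in this assay, that is, no change beyond the scatter, with wide uncertainty. For compound 3 the estimated value in this assay is 25 nM, with a range from 7 nM to 90 nM.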

Compound 3, half-maximal effective concentration: 3.9 nM
For compound 3 the middle estimate is 6.4-fold (0.81 log units) above the measured one; measured number below the stated range.
By their numbers in this assay, from the lowest: compound 3; then compounds 2 and 1 (each within the scatter of the next).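

The amino group shows that this position can respond clearly to a change of substituent, which compounds 1 and 2 alone could not show. In this assay, 6-aminopyridin-2-yl in place of 5-fluoropyridin-2-yl gives a 4.1-fold lower number from compound 2 to compound 3 (0.61 log units; beyond the scatter), and amino in place of cyano gives a 6.7-fold lower number from compound 1 to compound 3 (0.82 log units; beyond the scatter), so both steps lie beyond the scatter. Nothing available here explains why the amino group gives the lowest number of the three.

The compounds shown leave open whether the amino group itself is needed, since a methylamino, dimethylamino or hydroxy group in the same place would test this. They also leave open whether the amino group would give a similar step at the 5-position of the pyridine, where compound 2 carries its fluorine.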